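Swapping a Chlorophenyl Imine for a Nitrophenyl Imine

The compounds below may be only part of what the source reports. "The series", "measured", "known", "first", "only" and "open" are said of these compounds alone.

Measured compounds:
compound 1 `Clc1ccc(/C=N/c2sc3c(c2-c2nc4ccccc4s2)CCC3)cc1` — 380 ug/mL
compound 2 `Clc1ccc(/C=N/c2sc3c(c2-c2nc4ccccc4s2)CCCC3)cc1` — 431 ug/mL

In an ADME assay on HeLa cells (Homo sapiens) for cytotoxicity, read by MTT assay, with a stated time of 72 h (a higher number here means that more compound is tolerated, a lower number that less compound is tolerated), compound 2 gives 431 ug/mL. Compound 1 gives 380 ug/mL, and the two numbers lie within the usual scatter of each other, so neither compound can be called better tolerated than the other. Compound 3 `O=[N+]([O-])c1ccccc1/C=N/c1sc2c(c1-c1nc3ccccc3s1)CCCC2` differs from compound 2 by 2-nitrophenyl in place of 4-chlorophenyl on a carbon with a double bond to nitrogen. For the measured compounds named here, no measured pair shows what such a change does, so no step beyond the scatter is expected in this assay. The expected step of a 1.1-fold lower number from compound 2 to compound 3 (0.05 log units; within the scatter) is therefore small. Compound 3 is estimated at 380 ug/mL, with a range from 200 ug/mL to 650 ug/mL.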

Compound 3, half-maximal cytotoxic concentration: 369 ug/mL
Beside the measured number, compound 3's estimate is 1.0-fold (0.01 log units) above it; low and high end bracket the measured number.
By their numbers in this assay, from the lowest: compounds 3, 1 and 2 (each within the scatter of the next).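

In this assay putting 2-nitrophenyl in place of 4-chlorophenyl on a carbon with a double bond to nitrogen gives a close reading (a 1.2-fold lower number from compound 2 to compound 3 (0.07 log units; within the scatter)). This position therefore accepts a nitro-bearing ring as well as a chlorine-bearing one, with no difference that can be told from scatter. Nothing at hand explains why the two compounds read alike. Still open, going by these compounds, is whether a phenyl ring carrying an amine or a carboxylic acid would read the same here. Also open, on these data alone, is whether 2-nitrophenyl would behave alike on the core of compound 1.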